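The source may hold more compounds than are shown below. What is called first, only, known or untested is meant among the compounds shown, and "the series" means these compounds.

Compound 1 `O=S(=O)(Nc1ccc(-c2nc3ccccc3o2)cc1)c1cccs1` gives in an assay on isolated protein for inhibition of malate dehydrogenase, mitochondrial (Sus scrofa), with stated times of 45 min and 30 min; on this read-out lower numbers stand for stronger inhibition and higher numbers for weaker inhibition > 63000 nM, a limit of the assay.
Compound 2 `C=Cc1ccc(S(=O)(=O)Nc2ccc(-c3nc4ccccc4o3)cc2)cc1` gives in this assay > 63000 nM, again a limit.
Compound 3 `O=S(=O)(Nc1ccc(-c2nc3ccccc3o2)cc1)c1ccc(O)cc1` gives in this assay > 63000 nM, also a limit.

Compound 3 thus stands at the assay limit, where all three measured values sit (the limit of > 63000 nM in this assay, at which 3 of the 3 values shown sit). Compound 4 `O=S(=O)(Nc1ccc(-c2nc3ccccc3o2)cc1)c1ccc(Cl)cc1` differs from it by chloro in place of hydroxy on an aromatic carbon, so 4-hydroxyphenyl becomes 4-chlorophenyl. The step that the two limits leave unreadable from compound 2 to compound 3 also changes the group on that aromatic carbon, and a step that the two limits leave unreadable from compound 1 to compound 2 and a step that the two limits leave unreadable from compound 1 to compound 3 swap the whole ring on the sulfonyl sulfur; none has a readable size. Only the limit can be carried forward, so the expected step that the limit leaves unreadable from compound 3 to compound 4 is none beyond the scatter. Compound 4 is therefore estimated at 80000 nM in this assay, within 15000 nM to 400000 nM, most likely again reported only as a limit.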

Compound 4, half-maximal inhibitory concentration: > 63000 nM
Compound 4: only a limit was reported; the forecaster's own chance of this, stated with the estimate: 85%; the middle value lies beyond the limit too.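

For the compounds shown here, compound 4, like compound 1, compound 2 and compound 3, gives only a limit in this assay, so no step between these compounds can be read: the limit of > 63000 nM in this assay, at which 4 of the 4 values shown sit. The compounds shown leave open whether any group on the sulfonyl sulfur gives a measurable inhibition value.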